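The compounds below may be only part of what the source reports. "The series", "measured", "known", "first", "only" and "open" are said of these compounds alone.

Measured so far in an assay on cells for displacement of a labelled ligand from adenosine receptor A2b (Homo sapiens), read by scintillation counting and radioligand binding, with a stated time of 30 min, tested at 10 uM; on this read-out lower numbers stand for less inhibition and higher numbers for more inhibition at the one concentration tested (going by the name of the read-out):

Compound 1, `CN1CCN(c2nc(-c3ccc(Cl)c(Cl)c3)nc3[nH]cnc23)CC1`: compound 1 gives 24.1%.
Compound 2, `Cn1cnc2c(N3CCCCC3)nc(-c3cccc(O)c3O)nc21`: compound 2 gives 26%.
Compound 3, `CN1CCN(c2nc(-c3cccc(Cl)c3)nc3[nH]cnc23)CC1`: compound 3 gives 29.9%.

All three numbers sit in one band. Among the compounds with values here, compound 1 is nearest to compound 2, the gap being within the scatter, and furthest from compound 3, yet the only single-change step among the measured compounds, a number 5.8 percentage points higher from compound 1 to compound 3 (within the scatter), is also within the scatter; that step swaps hydrogen for chloro on an aromatic carbon and so does not touch the change considered next.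

Compound 4, `Clc1ccc(-c2nc(N3CCCCC3)c3nc[nH]c3n2)cc1Cl`, is the next member. Its relation to compound 1: piperidin-1-yl in place of 4-methylpiperazin-1-yl on an aromatic carbon. Within the data shown here, no measured step covers this change directly. Among the measured compounds shown here, the one indirect pointer is compound 2, which already carries piperidin-1-yl on its core, though with a different aromatic substituent and a methylated core, and which gives 26%, within the scatter of compound 1. On this basis no step beyond the scatter is expected in this assay .

The estimate for compound 4 is therefore 27%, with a range from 12% to 42%, which corresponds to an expected step of a number 2.9 percentage points higher from compound 1 to compound 4 (within the scatter).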

Compound 4, a percentage reported as inhibition, at one concentration (the size of the read-out at that concentration, not a potency): 0.7%
Compound 4: the middle estimate sits 26.3 percentage points above what was measured, and the stated range ends above it.
By their numbers in this assay, from the lowest: compound 4; then compounds 1, 2 and 3 (each within the scatter of the next).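

In this assay, within the data shown here, this position, on an aromatic carbon next to the ring nitrogen, responds to the choice of amine ring: a number 23.4 percentage points lower from compound 1 to compound 4 (beyond the scatter), the first step beyond the scatter, whereas the only earlier step, at the aryl group, a number 5.8 percentage points higher from compound 1 to compound 3 (within the scatter), stayed within it. The change itself is small, as piperidin-1-yl in place of 4-methylpiperazin-1-yl keeps a six-membered non-aromatic ring on the same carbon and goes from 2 nitrogen to 1 nitrogen and from 2 hydrogen-bond acceptors to 1 hydrogen-bond acceptor, so a small edit at this position is enough to move the read-out beyond the scatter. Nothing available explains the size of this step.

The compounds shown leave open whether the ring nitrogen or the methyl on it separates compound 1 from compound 4, a question that piperazin-1-yl without the methyl, morpholin-4-yl or an open-chain dimethylamino group at this position would address. From the compounds shown here alone, it also remains open whether the same change gives a step of similar size with the aryl group of compound 3.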